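The source may report more compounds than this note shows. Statements on the series, on what has been measured and on what is new or still open speak of the compounds shown alone.

Measured so far in a functional assay on T47D cells (Homo sapiens) for cytotoxicity, with a stated time of 72 h, tested at 50 ug/mL; on this read-out lower numbers stand for a weaker effect and higher numbers for a stronger effect at the one concentration tested:
compound 1 `Cc1ccc(N2CCN/C2=N\N)cc1`, 17%
compound 2 `N/N=C1\NCCN1c1ccccc1`, 0%

For the measured compounds named here, compound 2 stands lowest of the two numbers in this assay, with compound 1 the nearest, and the only measured step is a number 17 percentage points lower from compound 1 to compound 2 (beyond the scatter), a change of ring substituent. Compound 3 `N/N=C1\NCCN1c1cccc(Cl)c1` differs from compound 2 by chloro in place of hydrogen on an aromatic carbon. That single step suggests a ring substituent entering can move the read-out modestly upward from the unsubstituted ring, so a small rise is expected, a number 12 percentage points higher from compound 2 to compound 3 (beyond the scatter), though one step is thin ground. Compound 3 is estimated at 12%, range 0% to 30%.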

Compound 3, a percentage reported as inhibition, at one concentration (the size of the read-out at that concentration, not a potency): 0%
The estimate for compound 3 lay 12 percentage points above the measured number; low and high end bracket the measured number.
By their numbers in this assay, from the lowest: compounds 2 and 3 (each within the scatter of the next); then compound 1.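

In this assay, chloro in place of hydrogen on an aromatic carbon, meta to a group of 7 heavy atoms, gives no change at the digits printed from compound 2 to compound 3 (within the scatter). A ring substituent therefore does not raise the read-out in every case: the step of a number 17 percentage points lower from compound 1 to compound 2 (beyond the scatter) does not carry over to this chloro at this place. Nothing available bears on the reason for this result.

Open, on these data alone, is whether methyl at this same place would behave like chloro. Also open, as far as these compounds go, is whether an amine, a methoxy group or a carboxylic acid here would move the read-out.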